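Sulfur in place of selenium on the shared core

The source may hold more compounds than are shown below. What is called first, only, known or untested is meant among the compounds shown, and "the series" means these compounds.

Among the measured compounds shown here, compound 1 `CSc1cnc2ccccc2c1[Se]CC#CCO` stands lowest of the two numbers so far in a functional assay on CCRF-CEM cells (Homo sapiens) for antiproliferative activity, with a stated time of 72 h (a higher number here means a weaker inhibitor, a lower number a stronger inhibitor), where compound 1 gives 0.5 ug/mL. For the measured compounds named here, its nearest neighbour is compound 2 `CSc1cnc2ccccc2c1[Se]CC#CCOC(=O)c1ccccc1`, which in this assay gives 1.9 ug/mL; the one measured step is a 3.8-fold higher number from compound 1 to compound 2 (0.58 log units; beyond the scatter), benzoyl in place of hydrogen on an oxygen on a saturated carbon. Compound 3 `CSc1cnc2ccccc2c1SCC#CCO` keeps that hydrogen on the oxygen and instead alters the core: a group of 6 heavy atoms (4 carbon, 1 oxygen, 1 sulfur; no ring) in place of a group of 6 heavy atoms (4 carbon, 1 oxygen, 1 selenium; no ring), on an aromatic carbon. Going by the values given here, no measured step touches this aromatic carbon, so the benzoyl step does not bear on the change and gives no direction. With nothing to compare, the expectation for compound 3 is a number near that of compound 1, with a range wide enough for a modest step either way; the step of a 1.6-fold higher number from compound 1 to compound 3 (0.20 log units; within the scatter) is expected to remain within the scatter. Compound 3 is therefore estimated at 0.8 ug/mL, range 0.3 ug/mL to 2.5 ug/mL.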

Compound 3, concentration for 50% inhibition: 2.3 ug/mL
The estimate for compound 3 lay 2.9-fold (0.46 log units) below the measured number; measured number inside the range.
By their numbers in this assay, from the lowest: compound 1; then compounds 2 and 3 (each within the scatter of the next).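

Notes on this aromatic carbon: the first measured change here, sulfur in place of selenium within the group of 6 heavy atoms, gives a 4.6-fold higher number from compound 1 to compound 3 (0.66 log units; beyond the scatter) in this assay and so shows that the two atoms are not interchangeable at this position. The direction favours the selenium of compound 1, which now holds the lowest number of the three, and its steps to both other compounds are beyond the scatter. No available data account for the size of this step.

Going by these compounds, it remains open whether benzoyl on the oxygen would change the number on the sulfur core as it does on the selenium core. Also open, on these data alone, is how the selenium and sulfur groups compare when the methylsulfanyl group gives way to an amine, or when an amine replaces the terminal hydroxyl.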